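A few compounds are considered here, and "the series" means these few. Any claim that something is new, unique, unknown or untested is made for them only; others in the source may bear on it.

Of the compounds shown here, three have been tested in a functional assay on HepG2 cells (Homo sapiens) for cytotoxicity, read by MTT assay, with a stated time of 72 h; on this read-out higher numbers stand for weaker inhibition and lower numbers for stronger inhibition. Compound 1 `Cn1ccc2c(Oc3ccc(NC(=O)c4nn(-c5ccc(Cl)cc5)ccc4=O)cc3)ccnc21` gives in this assay only a limit, > 60000 nM. Compound 2 `COc1ccc(-n2ccc(=O)c(C(=O)Nc3ccc(Oc4ccnc5c4ccn5C)cc3)n2)cc1` differs from compound 1 by methoxy in place of chloro on an aromatic carbon; in this assay compound 2 also returns only a limit, > 60000 nM. Compound 3 `Cn1ccc2c(Oc3ccc(NC(=O)c4nn(-c5ccc(Cl)cc5)ccc4=O)cc3F)ccnc21` differs from compound 1 by fluoro in place of hydrogen on an aromatic carbon, and in this assay compound 3 likewise gives only a limit, > 60000 nM. Hence a step that the two limits leave unreadable from compound 1 to compound 2 and a step that the two limits leave unreadable from compound 1 to compound 3 cannot be sized, because every value sits at the limit of > 60000 nM in this assay, at which 3 of the 3 values shown sit. Compound 4 `COc1ccc(-n2ccc(=O)c(C(=O)Nc3ccc(Oc4ccnc5c4ccn5C)c(F)c3)n2)cc1` differs from compound 3 by methoxy in place of chloro on an aromatic carbon, the same change that separates compound 2 from compound 1. The step this estimate means, a step that the limit leaves unreadable from compound 3 to compound 4, is expected to remain unreadable. That expectation rests on compound 2, whose value > 60000 nM is a limit. Compound 4 is therefore expected to give 80000 nM in this assay.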

Compound 4, half-maximal inhibitory concentration: > 60000 nM
Compound 4 gave a limit, no number; the forecaster's own chance of this, stated with the estimate: 90%; the middle value lies beyond the limit too.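

Compound 4 adds no readable step: its steps from compound 3 and from compound 2 cannot be sized, because every value is only a limit: the limit of > 60000 nM in this assay, at which 4 of the 4 values shown sit.

The compounds shown leave open whether methoxy in place of chloro or fluoro in place of hydrogen changes cytotoxicity at all.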